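Replacing Trifluoromethyl with a Cyclopropylamide on the Shared Core

A few compounds are considered here, and "the series" means these few. Any claim that something is new, unique, unknown or untested is made for them only; others in the source may bear on it.

Two compounds share one core. Compound 1 `O=C(O)c1ccc2noc(-c3ccc(N4CCCCC4)cc3)c2c1` carries a piperidinyl group; in an assay for inhibition of inositol hexakisphosphate kinase 2 (Homo sapiens), read by colorimetric assay, coupled enzyme assay and malachite green, with a stated time of 120 min, in the presence of a further agent that is not named here (a higher number here means a weaker inhibitor, a lower number a stronger inhibitor), compound 1 gives 240 nM. For the measured compounds named here, compound 2 `O=C(O)c1ccc2noc(-c3cccc(C(F)(F)F)c3)c2c1` carries a trifluoromethyl group instead, and in this assay compound 2 gives 1460 nM, the highest of the two numbers measured so far and beyond the usual scatter from compound 1. Compound 3 `O=C(O)c1ccc2noc(-c3cccc(NC(=O)C4CC4)c3)c2c1` has not yet been measured; it differs from compound 2 in one place: (cyclopropylcarbonyl)amino in place of trifluoromethyl on an aromatic carbon. Going by the values given here, no step between two measured compounds shows the weight of such a change, so only the two values above can guide an expectation. Because compound 2 gives 1460 nM as the weaker of the pair, compound 3 is expected to move toward a somewhat lower number, a 1.8-fold lower number from compound 2 to compound 3 (0.26 log units; within the scatter), though the direction is uncertain. The estimate for compound 3 in this assay is 800 nM, with a range from 250 nM to 2500 nM.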

Compound 3, half-maximal inhibitory concentration: 410 nM
Beside the measured number, compound 3's estimate is 2.0-fold (0.29 log units) above it; the range from low to high includes it.
By their numbers in this assay, from the lowest: compounds 1 and 3 (each within the scatter of the next); then compound 2.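

At this aromatic carbon, meta to a large group, the substituent matters: in this assay, (cyclopropylcarbonyl)amino in place of trifluoromethyl gives a 3.6-fold lower number from compound 2 to compound 3 (0.55 log units; beyond the scatter). This is the only single-place step among the compounds shown, and although modest, it shows that this position tolerates a larger group with a hydrogen-bond donor, a hydrogen-bond acceptor and a three-membered ring, and that the number falls with this exchange. No supporting measurement bears on why the number falls.

The compounds shown leave open which part of the entering group accounts for the step, since the amide, its carbonyl and the cyclopropyl ring all change together. A plain amine or an acetylamino group on the same carbon would help separate these parts, and a longer chain in place of the cyclopropyl ring would test how much size this position accepts.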